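Compound 2 to compound 4: methyl in place of bromo

A few compounds are considered here, and "the series" means these few. Any claim that something is new, unique, unknown or untested is made for them only; others in the source may bear on it.

Of the compounds shown here, three with a shared core have been measured in a physicochemical assay for pharmacokinetics; a higher number here means that the compound lasts longer, a lower number that the compound disappears faster: compound 1 (`CC(NC(=O)N1C(=O)c2ccccc2S1(=O)=O)c1ccccc1`), compound 2 (`O=C(NCc1ccccc1Br)N1C(=O)c2ccccc2S1(=O)=O`) and compound 3 (`O=C(NCc1ccc(C(F)(F)F)cc1)N1C(=O)c2ccccc2S1(=O)=O`). Compound 1 gives > 166 h, which is a limit. Compound 3 gives > 166 h, also a limit. Compound 2 gives > 166 h, again a limit, so it has no exact half-life and stands with the others at the limit of > 166 h in this assay, at which 3 of the 3 values shown sit. Compound 4 (`Cc1ccccc1CNC(=O)N1C(=O)c2ccccc2S1(=O)=O`) differs from compound 2 by methyl in place of bromo on an aromatic carbon. No measured step sizes this change, and no change beyond the scatter is expected. The expected change is a step that the limit leaves unreadable from compound 2 to compound 4. In this assay the estimate for compound 4 is 180 h, with an expected range of 90 h to 360 h.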

Compound 4, half-life: > 166 h
Compound 4 ended at the assay's limit; the forecaster's own chance of this, stated with the estimate: 75%; the middle value is on the limit's open side.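

Compound 2 and compound 4 both end at a limit, so no step between them can be read: the limit of > 166 h in this assay, at which 4 of the 4 values shown sit.

The compounds shown leave open whether methyl in place of bromo changes the half-life at all.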